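Amide to urea on a shared pyrazole-bearing scaffold

The compounds below may be only part of what the source reports. "The series", "measured", "known", "first", "only" and "open" are said of these compounds alone.

Of the compounds shown here, three with a common core have been measured in a functional assay on NCI-H460 cells (Homo sapiens) for inhibition, read by sulforhodamine B assay, with a stated time of 48 h; a higher number here means a weaker inhibitor of growth, a lower number a stronger inhibitor of growth. Compound 1 `COc1cc(-c2nn(-c3cccc(NC(=O)Nc4cc(C(F)(F)F)cc(C(F)(F)F)c4)c3)cc2-c2ccncc2)ccc1Cl` gives 1870 nM. Compound 3 `O=C(Nc1cccc(-n2cc(-c3ccncc3)c(-c3ccc(Cl)c(O)c3)n2)c1)Nc1ccc(Cl)c(Cl)c1` gives 3570 nM. Compound 2 `COc1cc(-c2nn(-c3cccc(NC(=O)c4cccc(C(F)(F)F)c4)c3)cc2-c2ccncc2)ccc1Cl` gives 9270 nM, the highest of the three numbers; compound 3 is nearest to it and compound 1 furthest, and both gaps lie beyond the scatter. Compound 4 `COc1cc(-c2nn(-c3cccc(NC(=O)Nc4cccc(C(F)(F)F)c4)c3)cc2-c2ccncc2)ccc1Cl` has not yet been measured in this assay. It differs from compound 2 in one place: (3-(trifluoromethyl)phenyl)amino in place of 3-(trifluoromethyl)phenyl on a carbonyl carbon. Compound 4 thus carries a urea linkage like compound 1 and compound 3, whereas compound 2 carries a simple amide. Going by the values given here, no directly comparable pair of measured compounds isolates this change, but the two ureas sit at lower numbers than the amide. Compound 4 is therefore expected to show a step downward, a 2.6-fold lower number from compound 2 to compound 4 (0.42 log units; beyond the scatter), of a size beyond the scatter, partly because compound 1 gives 1870 nM with a closely related urea. Compound 4 is estimated at 3500 nM, within a range from 1200 nM to 10000 nM.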

Compound 4, concentration for total growth inhibition: 3530 nM
The estimate for compound 4 lay 1.0-fold (0.00 log units) below the measured number, and the stated range covers the measured number.
By their numbers in this assay, from the lowest: compounds 1, 4 and 3 (each within the scatter of the next); then compound 2.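

In this assay, the change from 3-(trifluoromethyl)phenyl to (3-(trifluoromethyl)phenyl)amino on a carbonyl carbon can now be read by itself, and it gives a 2.6-fold lower number from compound 2 to compound 4 (0.42 log units; beyond the scatter). The earlier compounds shown here offered no such pair, since the amide and the ureas also differed elsewhere. A second step now bears on the urea series: hydrogen in place of trifluoromethyl on an aromatic carbon gives a 1.9-fold higher number from compound 1 to compound 4 (0.28 log units; within the scatter), so this change cannot be told apart from the scatter. No measurement offered here bears on why the urea step arises.

The compounds shown leave open whether the step depends on the hydrogen of the entering amino group, which a methylamino group in the same place would test. They also leave open whether an oxygen, as in a carbamate, or a methylene group there would give a similar step.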